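From 2-methoxyphenyl to 4-methoxyphenyl on the amide nitrogen

The source may report more compounds than this note shows. Statements on the series, on what has been measured and on what is new or still open speak of the compounds shown alone.

In an ADME assay on HBZY-1 cells (Rattus norvegicus) for cytotoxicity, read by MTT assay, with a stated time of 2 h (a higher number here means a weaker inhibitor, a lower number a stronger inhibitor), compound 1 (`COc1ccccc1NC(=O)/C=C/c1ccccc1C(F)(F)F`) gives > 200000 nM as a limit of the assay. Compound 2 (`COc1ccccc1NC(=O)/C(C#N)=C/c1ccccc1C(F)(F)F`) gives > 200000 nM as a limit too, not a number. Compound 2 thus has only a limit to its name (the limit of > 200000 nM in this assay, at which 2 of the 2 values shown sit). Compound 3 (`COc1ccc(NC(=O)/C(C#N)=C/c2ccccc2C(F)(F)F)cc1`) carries 4-methoxyphenyl in place of 2-methoxyphenyl on an amide-type nitrogen. Going by the values given here, no measured step shows what such a change does in this assay for these compounds. The estimated step of a number no higher from compound 2 to compound 3 (the limit leaves the size open) is expected to stay within the usual scatter, in no set direction. Compound 3 is expected at 200000 nM with an estimated range from 100000 nM to 400000 nM around it.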

Compound 3, half-maximal inhibitory concentration: > 200000 nM
Compound 3 was reported as a limit; the forecaster's own chance of this, stated with the estimate: 70%; the middle value sits exactly at the limit.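

Compound 2 and compound 3 are both reported only as limits, so no step can be read between them: the limit of > 200000 nM in this assay, at which 3 of the 3 values shown sit. Going by these compounds, what 4-methoxyphenyl in place of 2-methoxyphenyl on an amide-type nitrogen does in this assay stays open.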